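Dithiocarbamate benzamides: nitro for chloro step

The compounds below may be only part of what the source reports. "The series", "measured", "known", "first", "only" and "open" are said of these compounds alone.

Measured in a functional assay on A-375 cells (Homo sapiens) for antiproliferative activity, read by CCK-8 assay, with a stated time of 72 h, tested at 2 uM; on this read-out lower numbers stand for a weaker effect and higher numbers for a stronger effect at the one concentration tested:
compound 1 `Nc1ccccc1NC(=O)c1ccc(CSC(=S)N2CCc3ccccc32)cc1` gives 25.7%;
compound 2 `Nc1ccccc1NC(=O)c1ccc(CSC(=S)N2CCCc3ccccc32)cc1` gives 26.5%;
compound 3 `Nc1ccccc1NC(=O)c1ccc(CSC(=S)N2CCc3cc(Cl)ccc32)cc1` gives 31.9%.

Compound 3 stands highest of the three numbers, but only narrowly: the step of a number 6.2 percentage points higher from compound 1 to compound 3 (within the scatter) and the step of a number 5.4 percentage points higher from compound 2 to compound 3 (within the scatter) both lie within the scatter, as does a number 0.8 percentage points higher from compound 1 to compound 2 (within the scatter). On the numbers shown, the three compounds are not separated from one another.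

Compound 4 `Nc1ccccc1NC(=O)c1ccc(CSC(=S)N2CCc3cc([N+](=O)[O-])ccc32)cc1` has not yet been measured. Its difference from compound 3 is nitro in place of chloro on an aromatic carbon. Among the measured compounds shown here, the one measured step that touches the same aromatic carbon is a number 6.2 percentage points higher from compound 1 to compound 3 (within the scatter), chloro in place of hydrogen, and it stayed within the scatter. For the measured compounds named here, no measured compound carries nitro, so nothing among the three shows how this group behaves in this assay. Going by the values given here, with the only comparable change having produced no step beyond the scatter, compound 4 is expected to give a number close to that of compound 3, with the estimated step of a number 0.1 percentage points higher from compound 3 to compound 4 (within the scatter) not exceeding the scatter in either direction. The estimate for compound 4 is therefore 32%, with a range from 18% to 46%.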

Compound 4, a percentage reported as inhibition, at one concentration (the size of the read-out at that concentration, not a potency): 16.9%
The estimate for compound 4 lay 15.1 percentage points above the measured number, outside the stated range (below it).
By their numbers in this assay, from the lowest: compounds 4, 1, 2 and 3 (each within the scatter of the next, the first and the last beyond it).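

In this assay, among the compounds shown here, the aromatic carbon carrying the substituent is the first place where one change in a single group separates two compounds: nitro in place of chloro gives a number 15 percentage points lower from compound 3 to compound 4 (beyond the scatter), whereas every step among the earlier compounds stayed within the scatter. Hydrogen is not separated from nitro at this carbon, as nitro in place of hydrogen gives a number 8.8 percentage points lower from compound 1 to compound 4 (within the scatter), and the earlier step from hydrogen to chloro was also within the scatter, so the position distinguishes only chloro from nitro, with the compound carrying hydrogen not separated from either. Nothing available bears on why these two groups differ at this carbon.

As far as these compounds go, it remains open whether other groups on the same carbon, such as an amine, a methoxy group or a carboxylic acid, would stand with nitro, with chloro or apart from both. Also open, from the compounds shown here alone, is whether the separation holds at other concentrations, since this read-out gives the size of the effect at one concentration and not a potency.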